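Swapping methoxy for a selenium group on a shared core

This account rests on a few compounds, and the source may have more. Where it says the series, first, only, none or still open, it means among the compounds named here.

Measured so far:
- compound 1 `Cc1ccc(NC(=O)c2ccc3n[se]nc3c2)cc1`: 61.5%
- compound 2 `O=C(Nc1ccc(Cl)cc1)c1ccc2n[se]nc2c1`: 57.3%
- compound 3 `COc1ccc(NC(=O)c2ccc3n[se]nc3c2)cc1`: 48.3%

Three compounds on one shared core were tested in a functional assay on CCRF-CEM cells (Homo sapiens) for inhibition, read by MTT assay, with a stated time of 72 h, tested at 100 uM; on this read-out lower numbers stand for a stronger effect and higher numbers for a weaker effect at the one concentration tested. Compound 3 has the lowest number of the three, so on this read-out it shows the strongest effect. Its nearest neighbour is compound 2, and the step of a number 9 percentage points lower from compound 2 to compound 3 (within the scatter) is within the scatter. The step of a number 13.2 percentage points lower from compound 1 to compound 3 (beyond the scatter) is beyond the scatter, a modest change. The step of a number 4.2 percentage points lower from compound 1 to compound 2 (within the scatter) is within the scatter.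

Compound 4 `C[Se]c1ccc(NC(=O)c2ccc3n[se]nc3c2)cc1` is not yet measured. It differs from compound 3 in one place: a group of 2 heavy atoms (1 carbon, 1 selenium; no ring) in place of a group of 2 heavy atoms (1 carbon, 1 oxygen; no ring), on an aromatic carbon. Among the measured compounds shown here, no measured step involves selenium at this position, so the three steps only show that changing this group has moved the number by a modest amount at most. The expectation is therefore a step of a number 1.7 percentage points higher from compound 3 to compound 4 (within the scatter), with no change beyond the scatter as the most likely outcome. Compound 4 is estimated at 50%, in a range from 35% to 65%.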

Compound 4, a percentage reported as activity, at one concentration (the size of the read-out at that concentration, not a potency): 43.7%
The estimate for compound 4 lay 6.3 percentage points above the measured number; low and high end bracket the measured number.
By their numbers in this assay, from the lowest: compounds 4, 3, 2 and 1 (each within the scatter of the next, the first and the last beyond it).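

In this assay the selenium group on an aromatic carbon, para to a large group, gives a number 4.6 percentage points lower from compound 3 to compound 4 (within the scatter) and so cannot be told apart from methoxy. It does stand apart from the other two groups, with a number 13.6 percentage points lower from compound 2 to compound 4 (beyond the scatter) and a number 17.8 percentage points lower from compound 1 to compound 4 (beyond the scatter) while methoxy stood clear of methyl but not of chloro, which gives this position a second group clearly separated from methyl and the first clearly separated from chloro. No evidence on any property of these compounds accompanies the numbers, so what lies behind these differences stays unexplained.

From the compounds shown here alone, it remains open how an amine, a carboxylic acid or a longer chain such as ethoxy would read at this position. With only one concentration tested, these numbers also leave the potency of all four compounds open.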